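Chloro to bromo exchange on the pendant aryl ring

The source may hold more compounds than are shown below. What is called first, only, known or untested is meant among the compounds shown, and "the series" means these compounds.

Four compounds are in view. Compound 1 `O=C(Nc1ccc(Oc2ccnc3[nH]ccc23)cc1)c1cn(-c2ccc(Cl)cc2)c2ccccc2c1=O` and compound 2 `O=C(Nc1ccc(Oc2ccnc3[nH]ccc23)cc1)c1cn(-c2ccc(Br)cc2)c2ccccc2c1=O` share one core; compound 3 `Cn1ccc2c(Oc3ccc(NC(=O)c4cn(-c5ccc(Cl)cc5)c5ccccc5c4=O)cc3F)ccnc21` and the as yet unmeasured compound 4 `Cn1ccc2c(Oc3ccc(NC(=O)c4cn(-c5ccc(Br)cc5)c5ccccc5c4=O)cc3F)ccnc21` share a second. The difference between the two cores is not broken down here.

In a functional assay on A549 cells (Homo sapiens) for inhibition, read by MTT assay, with a stated time of 72 h (a lower number here means a stronger inhibitor, a higher number a weaker inhibitor), compound 1 gives 650 nM. In this assay compound 2 gives 450 nM. For the measured compounds named here, the only change between them is bromo in place of chloro on an aromatic carbon, and it made a 1.4-fold lower number from compound 1 to compound 2 (0.16 log units; within the scatter). In this assay compound 3 gives 250 nM; its number sits within the scatter of compound 2 and beyond the scatter from compound 1.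

Compound 4 differs from compound 3 by bromo in place of chloro on an aromatic carbon. This is the same change as from compound 1 to compound 2, and it occurs twice in all among these compounds; the place is described identically in both cases, so it is the same change, not merely the same kind.

Going by the values given here, for compound 4 a step of a 1.3-fold lower number from compound 3 to compound 4 (0.12 log units; within the scatter) is expected, resting on a 1.4-fold lower number from compound 1 to compound 2 (0.16 log units; within the scatter), the one earlier instance of this change, which stayed within the scatter. The estimate for compound 4 in this assay is therefore 190 nM, with a plausible range from 90 nM to 400 nM; a number close to compound 3 is expected, since a single prior step within the scatter gives no firm direction.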

Compound 4, half-maximal inhibitory concentration: 1390 nM
The estimate for compound 4 lay 7.3-fold (0.86 log units) below the measured number, and the stated range ends below it.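

In this assay the change from 4-chlorophenyl to 4-bromophenyl did not carry over from one core to the other: the same change on two cores in this assay, a 1.4-fold lower number (0.16 log units; within the scatter) from compound 1 to compound 2 and a 5.6-fold higher number (0.75 log units; beyond the scatter) from compound 3 to compound 4, 8.0-fold (0.90 log units) apart, beyond the scatter of two such steps. On the core of compound 3 the exchange gave a 5.6-fold higher number from compound 3 to compound 4 (0.75 log units; beyond the scatter), a loss of activity, while on the core of compound 1 the step stayed within the scatter, and the outcome on one core therefore gave no usable guide to the outcome on the other. This does not show why the two cores part, and with a single pair on each core it does not show whether the loss belongs to bromo in general or how the exchange would behave on any third core.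

Open is which part of the difference between the cores goes with the divergent step, the fluoro or the methyl group that compound 3 and compound 4 carry and compound 1 and compound 2 lack, since no compound shown has one without the other. Also open, on these data alone, is how other groups in place of the chloro, such as iodo, methoxy or nitrile, would behave on each core.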